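This account rests on a few compounds, and the source may have more. Where it says the series, first, only, none or still open, it means among the compounds named here.

Compound 1 `O=C(Nc1cccc(-n2cc(-c3ccncc3)c(-c3cc(O)cc(Cl)c3)n2)c1)Nc1ccc(Cl)c(C(F)(F)F)c1` and compound 2 `COc1cc(Cl)cc(-c2nn(-c3cccc(NC(=O)Nc4ccc(Cl)c(C(F)(F)F)c4)c3)cc2-c2ccncc2)c1` share one core; compound 3 `O=C(Nc1cccc(-n2cc(-c3ccncc3)c(-c3cc(O)cc(Cl)c3)n2)c1)c1cc(C(F)(F)F)cc(C(F)(F)F)c1` and the unmeasured compound 4 `COc1cc(Cl)cc(-c2nn(-c3cccc(NC(=O)c4cc(C(F)(F)F)cc(C(F)(F)F)c4)c3)cc2-c2ccncc2)c1` share another, and the difference between the two cores is not broken down here. In a functional assay on SNB-19 cells (Homo sapiens) for inhibition, read by sulforhodamine B assay, with a stated time of 48 h, tested at 10 uM (on this read-out lower numbers stand for a stronger effect and higher numbers for a weaker effect at the one concentration tested), compound 1 gives 44.5% and compound 2 gives 28.1%. The change between them, (methyl in place of hydrogen on an oxygen on an aromatic ring), gave a number 16.4 percentage points lower from compound 1 to compound 2 (beyond the scatter). In this assay compound 3 gives 63.1%, the highest of the three measured numbers. Compound 4 carries the same change against compound 3, (methyl in place of hydrogen on an oxygen on an aromatic ring), at the same place. For the measured compounds named here, because a number 16.4 percentage points lower from compound 1 to compound 2 (beyond the scatter) is the only precedent, a step of similar size is expected, a number 16.1 percentage points lower from compound 3 to compound 4 (beyond the scatter), with a wide range. Compound 4 is estimated at 47%, between 33% and 61%.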

Compound 4, a percentage reported as activity, at one concentration (the size of the read-out at that concentration, not a potency): 86.4%
Beside the measured number, compound 4's estimate is 39.4 percentage points below it; measured number above the stated range.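

On the core of compound 3, hydroxy to methoxy gives a number 23.3 percentage points higher from compound 3 to compound 4 (beyond the scatter) in this assay, a weaker effect at the one concentration tested. The change does not keep its direction from one core to the other: the same change on two cores in this assay, a number 16.4 percentage points lower (beyond the scatter) from compound 1 to compound 2 and a number 23.3 percentage points higher (beyond the scatter) from compound 3 to compound 4, 39.7 percentage points apart, beyond the scatter of two such steps. For the compounds shown here, with only two pairs, this shows that the step cannot simply be carried between these cores, but not which part of the difference between the cores goes with the reversal, nor how the step would run on a third core.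

The compounds shown leave open whether a longer chain on that oxygen, or an amine in place of the hydroxy, would follow the step seen on either core.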